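A few compounds are considered here, and "the series" means these few. Any claim that something is new, unique, unknown or untested is made for them only; others in the source may bear on it.

In an ADME assay on HEK293 cells (Homo sapiens) for cytotoxicity, read by resazurin assay, with a stated time of 48 h (on this read-out lower numbers stand for higher toxicity in this test and higher numbers for lower toxicity in this test), compound 1 (`O=S(=O)(Nc1ccc2oc(-c3ccccc3)nc2c1)c1cccc(C(F)(F)F)c1`) stands at > 100000 nM as a limit of the assay and not as a number. Within the data shown here, compound 2 (`Cc1ccccc1S(=O)(=O)Nc1ccc2oc(-c3ccccc3)nc2c1`) gives 57000 nM in the same test, and this is the only true number available so far, so it has no second number to be ranked against. Among the measured compounds shown here, no pair of tested compounds differs in just one place, which leaves the two results simply side by side. Compound 3 (`O=S(=O)(Nc1ccc2oc(-c3ccccc3)nc2c1)c1cccc(F)c1`) is the next to be read, and it departs from compound 2 on a sulfonyl sulfur, with 3-fluorophenyl in place of 2-methylphenyl (3-fluorophenyl in place of 2-methylphenyl on a sulfonyl sulfur). In this assay no shift beyond the scatter is expected from this exchange, and the expectation takes compound 2 at 57000 nM as its anchor. The expected move, a 1.3-fold higher number from compound 2 to compound 3 (0.12 log units; within the scatter) as estimated, has no firm direction. A result reported only as a limit would also fit this expectation for compound 3. In this assay the estimate for compound 3 is 75000 nM as an expected value, with an expected range from 35000 nM to 100000 nM around it.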

Compound 3, half-maximal cytotoxic concentration: 68000 nM
Compound 3: middle estimate off by 1.1-fold (0.04 log units), on the high side, within the range that was stated.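

In this assay, among these compounds, the exchange on the sulfonyl sulfur gives the first step that joins two true numbers: a 1.2-fold higher number from compound 2 to compound 3 (0.08 log units; within the scatter). On a sulfonyl sulfur whose other neighbour is the sulfonamide nitrogen, 3-fluorophenyl and 2-methylphenyl therefore cannot be told apart in this test, and the two compounds carry no order. The second step, with fluoro in place of trifluoromethyl on an aromatic carbon, is an at least 1.4-fold lower number from compound 1 to compound 3 (0.16 log units; that floor lies within the scatter), and it gives only a floor, so its true size remains unknown: the limit of > 100000 nM in this assay, at which 1 of the 3 values shown sits.

The compounds shown leave open whether a group other than a substituted phenyl on the sulfonyl sulfur, such as a piperidine or a longer alkyl chain, would give a step beyond the scatter in this assay. The shared core is also the same in all three compounds, so the effect of an amine or a carboxylic acid placed on it remains an open question, as does the true value of compound 1.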